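One More Methoxy on a Growth Inhibitor

The source may report more compounds than this note shows. Statements on the series, on what has been measured and on what is new or still open speak of the compounds shown alone.

In a functional assay on A549 cells (Homo sapiens) for inhibition, read by MTT assay, with a stated time of 24 h (on this read-out lower numbers stand for stronger inhibition of growth and higher numbers for weaker inhibition of growth), compound 2 `COc1ccc(C(=O)n2c(-c3cn(C)c4ccccc34)nc3ccccc32)cc1OC` gives the lowest of three numbers (3100 nM), while compound 1 `COc1cccc(C(=O)n2c(-c3cn(C)c4ccccc34)nc3ccccc32)c1` gives 10200 nM and compound 3 `Cn1cc(-c2nc3ccccc3n2C(=O)c2cccc(Br)c2)c2ccccc21` gives 34200 nM. Compound 4 `COc1ccc2c(c1)c(-c1nc3ccccc3n1C(=O)c1ccc(OC)c(OC)c1)cn2C` differs from compound 2 by one change: methoxy in place of hydrogen on an aromatic carbon that is, methoxy in place of hydrogen on an aromatic carbon of a six-membered aromatic ring of carbon only. Among the measured compounds shown here, the closest precedent is a 3.3-fold lower number from compound 1 to compound 2 (0.52 log units; beyond the scatter) where the same swap occurred elsewhere in the molecule. The bromo steps, a 3.4-fold higher number from compound 1 to compound 3 (0.53 log units; beyond the scatter) and an 11-fold higher number from compound 2 to compound 3 (1.04 log units; beyond the scatter) bear on it less. A small drop in this assay is therefore expected, and the estimated change is a 1.6-fold lower number from compound 2 to compound 4 (0.19 log units; within the scatter) at most a modest one. For compound 4 the expected value is 2000 nM (estimated range 700 nM to 6000 nM).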

Compound 4, concentration for 50% growth inhibition: 2700 nM
For compound 4 the middle estimate is 1.4-fold (0.13 log units) below the measured one; low and high end bracket the measured number.
By their numbers in this assay, from the lowest: compounds 4 and 2 (each within the scatter of the next); then compound 1; then compound 3.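

In this assay, methoxy in place of hydrogen on this six-membered aromatic ring, part of a fused system of two rings, gives a 1.1-fold lower number from compound 2 to compound 4 (0.06 log units; within the scatter), so this position accepts the extra group with no clear change in the number. The same swap elsewhere in the molecule gave a 3.3-fold lower number from compound 1 to compound 2 (0.52 log units; beyond the scatter), so its effect on growth inhibition depends on where it sits. Nothing available explains this difference between the two positions.

Still open, on these data alone, is whether a different group at this position, such as an amine or a carboxylic acid, would move the number beyond the scatter.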